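Thiazolyl hydrazine sulfonamides: an acetyl on the ring

This account rests on a few compounds, and the source may have more. Where it says the series, first, only, none or still open, it means among the compounds named here.

Measured compounds:
Compound 1 `CC(=O)c1sc(NNS(=O)(=O)c2ccc(C)cc2)nc1C` gives 9840 nM in a functional assay on DU-145 cells (Homo sapiens) for inhibition, read by XTT assay, with a stated time of 72 h; a higher number here means a weaker inhibitor, a lower number a stronger inhibitor.
Compound 2 `CC(=O)N(c1nc(C)cs1)N(C(C)=O)S(=O)(=O)c1ccc(C)cc1` gives 7630 nM in this assay.
Compound 3 `CC(=O)N(c1nc(-c2ccccc2)cs1)N(C(C)=O)S(=O)(=O)c1ccc(C)cc1` reaches only a limit in this assay, > 58200 nM.

Compound 2 holds the lowest of the two numbers shown; compound 1 sits within the scatter of it, so no order between the two can be stated. Going by the values given here, the one step measured, an at least 7.6-fold higher number from compound 2 to compound 3 (0.88 log units; beyond the scatter), is the only shift beyond the scatter, and the value of compound 3 is a limit (the limit of > 58200 nM in this assay, at which 1 of the 3 values shown sits).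

Compound 4 `CC(=O)c1sc(N(C(C)=O)N(C(C)=O)S(=O)(=O)c2ccc(C)cc2)nc1C` differs from compound 2 by acetyl in place of hydrogen on an aromatic carbon. The change on the ring is smaller than the phenyl-for-methyl exchange that produced an at least 7.6-fold higher number from compound 2 to compound 3 (0.88 log units; beyond the scatter), and compound 1, which already carries this acetyl on its ring with a different hydrazine substitution, gives a number close to that of compound 2. Against that background no step beyond the scatter is expected from compound 2 to compound 4 in this assay, with a slight drift toward a higher number the more likely direction.

The estimate for compound 4 is 11000 nM, with a range from 4500 nM to 30000 nM, corresponding to an expected step of a 1.4-fold higher number from compound 2 to compound 4 (0.16 log units; within the scatter).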

Compound 4, half-maximal inhibitory concentration: 53500 nM
The estimate for compound 4 lay 4.9-fold (0.69 log units) below the measured number; the measured number lies above the stated range.
By their numbers in this assay, from the lowest: compounds 2 and 1 (each within the scatter of the next); then compound 4. At a limit, above all of these: compound 3.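

In this assay, acetyl in place of hydrogen on the aromatic carbon next to the ring sulfur gives a 7.0-fold higher number from compound 2 to compound 4 (0.85 log units; beyond the scatter), so this carbon is not a silent place on the core of compound 2. The earlier step concerned only the ring atom that bears the methyl group, and the new step adds a second ring position at which a single change moves the number beyond the scatter. The comparison with the earlier step remains open-ended, since compound 3 gives a limit and not a number: the limit of > 58200 nM in this assay, at which 1 of the 4 values shown sits.

Compound 1 carries the same 5-acetyl-4-methyl-1,3-thiazol-2-yl group as compound 4 but has a different hydrazine substitution, so that pair is not a single change and cannot show whether the effect of the ring acetyl depends on the acetyl groups on the hydrazine. Also open, as far as these compounds go, is whether the step belongs to acetyl itself or would be shared by other groups on this carbon, such as a carboxylic acid, an amine or a longer acyl chain.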